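Swapping 1H-indol-3-yl for 4-bromophenyl: compound 1 to compound 4

The compounds below may be only part of what the source reports. "The series", "measured", "known", "first", "only" and "open" are said of these compounds alone.

In a functional assay on DU-145 cells (Homo sapiens) for inhibition, read by trypan blue exclusion, with a stated time of 96 h (on this read-out higher numbers stand for weaker inhibition of growth and lower numbers for stronger inhibition of growth), compound 1 `O=C(/C(=C\c1c[nH]c2ccccc12)S(=O)(=O)Cc1ccc(F)cc1)c1ccc(Cl)cc1` gives 50000 nM. Compound 2 `Cc1ccc(CS(=O)(=O)/C(=C/c2c[nH]c3ccccc23)C(=O)c2ccc(Cl)cc2)cc1` gives 25000 nM. For the measured compounds named here, the only measured step, methyl in place of fluoro on an aromatic carbon, is a 2.0-fold lower number from compound 1 to compound 2 (0.30 log units; within the scatter). Compound 3 `Cc1ccc(S(=O)(=O)/C(=C/c2ccc(F)cc2F)C(=O)c2ccc(Br)cc2)cc1` gives > 100000 nM, which is a limit of the assay and not a number.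

Compound 4 `O=C(/C(=C\c1ccc(Br)cc1)S(=O)(=O)Cc1ccc(F)cc1)c1ccc(Cl)cc1` carries 4-bromophenyl in place of 1H-indol-3-yl on a double-bonded chain carbon bound to a double-bonded chain carbon. The measured step concerns a different place in the molecule, so it gives no direct size for this change. With nothing else to go on, no shift beyond the scatter is expected in this assay, and the starting point remains compound 1 at 50000 nM. Compound 4 may also end up reported at the limit of > 100000 nM in this assay, at which 1 of the 3 values shown sits. The expected change is a 1.2-fold higher number from compound 1 to compound 4 (0.08 log units; within the scatter). For compound 4 the estimated value is 60000 nM, with an expected range from 20000 nM to 150000 nM.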

Compound 4, concentration for 50% growth inhibition: > 100000 nM
Compound 4 ended at the assay's limit; the forecaster's own chance of this, stated with the estimate: 35%; middle value at least 1.6-fold (0.22 log units) away from the limit.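

Notes on the group on the double-bonded chain carbon: in this assay, the earlier step concerned a different place, and 4-bromophenyl in place of 1H-indol-3-yl now gives an at least 2.0-fold higher number from compound 1 to compound 4 (0.30 log units; that floor lies within the scatter). This is a floor and not a size, so the true shift may be larger, but the printed floor alone does not set the change apart from the scatter. Compound 4 gives > 100000 nM, which is a limit of the assay, and the series now reaches that limit a second time: the limit of > 100000 nM in this assay, at which 2 of the 4 values shown sit.

On these data alone, it remains open whether the loss of the five-membered ring and its hydrogen-bond donor or the entry of bromine matters more for this result. A 4-aminophenyl group or a 1-methyl-1H-indol-3-yl group in this place would help separate these two parts of the change.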